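A few compounds are considered here, and "the series" means these few. Any claim that something is new, unique, unknown or untested is made for them only; others in the source may bear on it.

Compound 3 `O=[N+]([O-])c1ccc(COc2ccccc2Nc2ncnc3cc4c(cc23)OCCOCCO4)cc1` is the only one of the three measured compounds that gives a number in a functional assay on A549 cells (Homo sapiens) for antiproliferative activity, read by MTT assay, with a stated time of 72 h; on this read-out higher numbers stand for weaker inhibition and lower numbers for stronger inhibition: compound 3 gives 28400 nM. Compound 1 `c1ccc(COc2ccccc2Nc2ncnc3cc4c(cc23)OCCOCCO4)cc1` differs from it by hydrogen in place of nitro on an aromatic carbon, and this change produced an at least 3.5-fold higher number from compound 3 to compound 1 (0.54 log units; beyond the scatter), ending at the limit of > 100000 nM in this assay, at which 2 of the 3 values shown sit. For compound 1 in this assay the value > 100000 nM is a limit of the assay, not a number. Compound 2 `O=[N+]([O-])c1ccc(COc2ccc(Nc3ncnc4cc5c(cc34)OCCOCCOCCOCCO5)cc2)cc1` likewise reaches only a limit in this assay, > 100000 nM. The difference between the cores of compound 2 and compound 3 is not broken down here. Compound 4 `c1ccc(COc2ccc(Nc3ncnc4cc5c(cc34)OCCOCCOCCOCCO5)cc2)cc1` is not yet measured; it differs from compound 2 by hydrogen in place of nitro on an aromatic carbon, the same change as between compound 3 and compound 1. Because compound 2 already sits at the limit of > 100000 nM in this assay, at which 2 of the 3 values shown sit, and this change gave an at least 3.5-fold higher number from compound 3 to compound 1 (0.54 log units; beyond the scatter), compound 4 is expected to remain there too, a step that the limit leaves unreadable from compound 2 to compound 4. The estimate for compound 4 in this assay is 150000 nM.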

Compound 4, half-maximal inhibitory concentration: 29500 nM
Compound 4: middle estimate off by 5.1-fold (0.71 log units), on the high side, outside the stated range (below it).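

In this assay, hydrogen in place of nitro on the aromatic carbon gave an at least 3.3-fold lower number from compound 2 to compound 4 (0.53 log units; beyond the scatter), a change in the opposite direction to the earlier step on the other core. The effect of this change therefore did not carry from one core to the other, as the two steps ran in opposite directions: the same change on two cores in this assay, an at least 3.5-fold higher number (0.54 log units; beyond the scatter) from compound 3 to compound 1 and an at least 3.3-fold lower number (0.53 log units; beyond the scatter) from compound 2 to compound 4, at least 11-fold (1.07 log units) apart, beyond the scatter of two such steps. Going by these compounds, compound 1 and compound 2 each stand at a limit and not at a number, so the full size of both steps stays unknown, and two pairs give no rule for other cores: the limit of > 100000 nM in this assay, at which 2 of the 4 values shown sit.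

The compounds shown leave open which of the differences between the two cores sets the direction of the step. They also leave open how an amine, a methoxy group or a fluorine in place of nitro on the same aromatic carbon would read in this assay.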